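Indole nitrogen methylation: working notes on compound 4

The source may hold more compounds than are shown below. What is called first, only, known or untested is meant among the compounds shown, and "the series" means these compounds.

Measured so far:
compound 1 `COc1cc(-c2ccnc3cc(-c4c[nH]c5ccccc45)nn23)cc(OC)c1OC` — 195 nM
compound 2 `COc1cc(-c2ccnc3cc(-c4ccc5c(ccn5C)c4)nn23)cc(OC)c1OC` — 19 nM
compound 3 `COc1cc(-c2ccnc3cc(-c4ccc(C(F)(F)F)cc4)nn23)cc(OC)c1OC` — 1840 nM

All three share one core and differ only in the aryl group on it. In a functional assay on HeLa cells (Homo sapiens) for inhibition, read by CCK-8 assay, with a stated time of 48 h (on this read-out lower numbers stand for stronger inhibition and higher numbers for weaker inhibition), compound 1 sits second highest of the three numbers; its nearest neighbour is compound 3 with a 9.4-fold higher number from compound 1 to compound 3 (0.97 log units; beyond the scatter), its furthest is compound 2 with a 10-fold lower number from compound 1 to compound 2 (1.01 log units; beyond the scatter). The remaining pair gives a 97-fold higher number from compound 2 to compound 3 (1.99 log units; beyond the scatter).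

Compound 4 `COc1cc(-c2ccnc3cc(-c4cn(C)c5ccccc45)nn23)cc(OC)c1OC` is not yet measured. It differs from compound 1 by methyl in place of hydrogen on an aromatic nitrogen. Going by the values given here, no measured step is a pure methylation of this kind: the step from compound 1 to compound 2 introduces a methyl on the indole nitrogen, but at the same time moves the attachment from 1H-indol-3-yl to 1-methyl-1H-indol-5-yl, so it bears on compound 4 only in part, and the step from compound 1 to compound 3 exchanges the whole indole for 4-(trifluoromethyl)phenyl and bears on it little. The closest evidence thus points downward, but mixed with a change of attachment. A small step is expected, at most modest, most likely toward a lower number, and possibly none beyond the scatter.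

Compound 4 is estimated at 110 nM, range 35 nM to 400 nM. This estimate means a step of a 1.8-fold lower number from compound 1 to compound 4 (0.25 log units; within the scatter), expected to stay modest.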

Compound 4, half-maximal inhibitory concentration: 399 nM
Compound 4: middle estimate off by 3.6-fold (0.56 log units), on the low side; the range from low to high includes it.
By their numbers in this assay, from the lowest: compound 2; then compound 1; then compound 4; then compound 3.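

In this assay, methyl in place of hydrogen on the aromatic nitrogen of the 1H-indol-3-yl group gives a 2.0-fold higher number from compound 1 to compound 4 (0.31 log units; beyond the scatter) and so, at this attachment, goes with a higher number, a direction the earlier mixed step could not show. With the methyl on the nitrogen in both compounds, the change of attachment alone gives a 21-fold higher number from compound 2 to compound 4 (1.32 log units; beyond the scatter), so the attachment point of the indole carries a far larger step than the methyl does in this pair, while exchanging 4-(trifluoromethyl)phenyl for the methylated indole still gives a 4.6-fold lower number from compound 3 to compound 4 (0.66 log units; beyond the scatter). Nothing at hand accounts for any of these steps.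

Open is whether methyl in place of hydrogen steps the same way on a 1H-indol-5-yl group, as the compounds shown offer that comparison only for the 1H-indol-3-yl attachment. Also open, going by these compounds, is how the aromatic nitrogen responds to a group larger than methyl, such as an ethyl group, a longer chain or a chain ending in an amine or a carboxylic acid.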